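Chalcone series: para substituent swap to hydroxy

The compounds below may be only part of what the source reports. "The series", "measured", "known", "first", "only" and "open" are said of these compounds alone.

Measured compounds in an assay on isolated protein for inhibition of Amine oxidase [flavin-containing] B (Homo sapiens); on this read-out higher numbers stand for weaker inhibition and lower numbers for stronger inhibition:
compound 1 `CCOc1ccc(C(=O)/C=C/c2ccc(Br)cc2)cc1` gives 210 nM
compound 2 `CCOc1ccc(C(=O)/C=C/c2ccc(CC)cc2)cc1` gives 210 nM
compound 3 `CCOc1ccc(C(=O)/C=C/c2ccc(C(F)(F)F)cc2)cc1` gives 210 nM

Compound 3 stands level with compound 1 and compound 2 at the digits shown; its nearest neighbour is compound 1 and its furthest is compound 2, both within the scatter. The three measured steps, no change at the digits printed from compound 1 to compound 2 (within the scatter), no change at the digits printed from compound 1 to compound 3 (within the scatter) and no change at the digits printed from compound 2 to compound 3 (within the scatter), were all flat, so swapping bromo, ethyl and trifluoromethyl on the aromatic carbon left this assay unmoved.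

Compound 4 `CCOc1ccc(C(=O)/C=C/c2ccc(O)cc2)cc1` is not yet measured. It differs from compound 3 by hydroxy in place of trifluoromethyl on an aromatic carbon. All three measured steps bear on this one, since each also exchanged the group on that aromatic carbon, and each was a step of no size. On those steps alone no change beyond the scatter would be expected. The change to hydroxy, however, is unlike any measured step in what it counts, so the expectation is held loosely and leans toward weaker inhibition in this assay, an expected step of a 3.8-fold higher number from compound 3 to compound 4 (0.58 log units; beyond the scatter). Compound 4 is therefore estimated at 800 nM, with a range from 200 nM to 4000 nM.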

Compound 4, half-maximal inhibitory concentration: 210 nM
Compound 4: middle estimate off by 3.8-fold (0.58 log units), on the high side; the range from low to high includes it.
By their numbers in this assay, from the lowest: compounds 1, 2, 3 and 4 (each within the scatter of the next).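

In this assay hydroxy in place of trifluoromethyl gave no change at the digits printed from compound 3 to compound 4 (within the scatter) and hydroxy in place of ethyl gave no change at the digits printed from compound 2 to compound 4 (within the scatter) while hydroxy in place of bromo gave no change at the digits printed from compound 1 to compound 4 (within the scatter) and so the flat picture now takes in a fourth group on this aromatic carbon. Until now the exchanges at this place, para to a large group, had involved only bromo, ethyl and trifluoromethyl, whereas hydroxy is a single heavy atom carrying a hydrogen-bond donor and a hydrogen-bond acceptor, and trifluoromethyl has four heavy atoms and neither, yet this difference left the read-out where it was. Nothing available explains why these four compounds read alike.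

From the compounds shown here alone, whether any group on this aromatic carbon can shift the number remains open, and an amine, a carboxylic acid or a longer chain there could each give a different answer in this assay. Going by these compounds, it is also open whether this indifference would persist if the ethoxy group on the other side of the shared core were exchanged for another group.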